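A few compounds are considered here, and "the series" means these few. Any claim that something is new, unique, unknown or untested is made for them only; others in the source may bear on it.

Compounds measured in an ADME assay on BJ cells (Homo sapiens) for cytotoxicity, read by CellTiter-Glo and resazurin assay, with a stated time of 72 h; on this read-out higher numbers stand for an effect only at larger amounts of compound and lower numbers for an effect already at smaller amounts:

- compound 1, `COc1cccc(-c2ccc(C(=O)N(Cc3cccc(OCCCCCC(=O)O)c3)C(C)C)cc2)c1`: compound 1 gives > 20900 nM, which is a limit of this assay.
- compound 2, `CC(C)N(Cc1cccc(OCCCCCC(=O)O)c1)C(=O)c1ccc(-c2ccc3c(c2)OCCO3)cc1`: compound 2 gives > 21900 nM, a limit of this assay.
- compound 3, `CC(C)N(Cc1cccc(OCCCCCC(=O)O)c1)C(=O)c1ccc(-c2cc3ccccc3n2S(=O)(=O)c2ccccc2)cc1`: compound 3 gives > 26000 nM, a limit of this assay.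

Among the compounds with values here, compound 1 stands only at a limit in this assay (the limit of > 20900 nM in this assay, at which 1 of the 3 values shown sits), and the two further values shown are likewise limits (the limit of > 21900 nM in this assay, at which 1 of the 3 values shown sits, (the limit of > 26000 nM in this assay, at which 1 of the 3 values shown sits)); no compound has a read number, so none can be placed relative to another.

Compound 4, `CC(C)N(Cc1cccc(OCCCCCC(=O)O)c1)C(=O)c1ccc(-c2cccc(Cl)c2)cc1`, is not yet measured. It differs from compound 1 by chloro in place of methoxy on an aromatic carbon.

Within the data shown here, the one step that bears on this place is a step that the two limits leave unreadable from compound 1 to compound 2, which swaps the 3-methoxyphenyl at the same position; its size is not readable from the two limits. Among the measured compounds shown here, no step shows any read change in this assay, so no direction beyond the scatter is expected for the chloro in place of methoxy change, and the most likely outcome is again a limit.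

Compound 4 is therefore expected at 25000 nM, with a range of 10000 nM to 80000 nM, and the estimated step that the limit leaves unreadable from compound 1 to compound 4 is expected to be within the scatter.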

Compound 4, half-maximal effective concentration: > 21900 nM
Compound 4 was reported as a limit; the forecaster's own chance of this, stated with the estimate: 85%; the middle value lies beyond the limit too.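

No step can be read among compound 1, compound 2 and compound 4 in this assay: all three stand only at limits of the assay. The compounds shown leave open whether chloro in place of methoxy, or any other change at this place, shifts the read-out at all.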